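This account rests on a few compounds, and the source may have more. Where it says the series, first, only, none or still open, it means among the compounds named here.

Measured compounds in a functional assay on MDA-MB-231 cells (Homo sapiens) for antiproliferative activity, read by sulforhodamine B assay, with a stated time of 72 h; a higher number here means a weaker inhibitor, a lower number a stronger inhibitor:
compound 1 `COc1cc2occ(-c3csc4ccccc34)c(=O)c2c(OC)c1OC`, 820 nM
compound 2 `COc1cc2occ(-c3csc4ccccc34)c(=O)c2c(OC)c1O`, > 10000 nM
compound 3 `COc1ccc(O)c(C(=O)/C=C/c2csc3ccccc23)c1`, 760 nM

Compound 2 carries a hydroxy group on its core. In this assay compound 2 gives only a limit, > 10000 nM, not a number; the set of three values includes (the limit of > 10000 nM in this assay, at which 1 of the 3 values shown sits). Compound 1 differs from compound 2 by one change, (methyl in place of hydrogen on an oxygen on an aromatic ring), and this gave an at least 12-fold lower number from compound 2 to compound 1 (1.08 log units; beyond the scatter).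

Compound 3 is built on a different core from compound 2; the difference between the two cores is not broken down here. In this assay compound 3 gives 760 nM, and against compound 1 it gives a number within the scatter, so no order between them can be stated.

Compound 4 `COc1ccc(OC)c(C(=O)/C=C/c2csc3ccccc23)c1` has not yet been measured. It differs from compound 3 by methyl in place of hydrogen on an oxygen on an aromatic ring, the same change as between compound 2 and compound 1, at a place described in the same words. The earlier step was large, yet compound 3 already gives a low number, and the cores differ, so a smaller step is expected: a 1.5-fold lower number from compound 3 to compound 4 (0.18 log units; within the scatter). Compound 4 is therefore estimated at 500 nM, within 150 nM to 3000 nM.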

Compound 4, half-maximal inhibitory concentration: 5400 nM
The estimate for compound 4 lay 11-fold (1.03 log units) below the measured number; measured number above the stated range.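

In this assay the hydroxy to methoxy change did not carry over from one core to the other, for on the core of compound 3 it gave a 7.1-fold higher number from compound 3 to compound 4 (0.85 log units; beyond the scatter), and the two steps run in opposite directions: the same change on two cores in this assay, an at least 12-fold lower number (1.08 log units; beyond the scatter) from compound 2 to compound 1 and a 7.1-fold higher number (0.85 log units; beyond the scatter) from compound 3 to compound 4, at least 86-fold (1.93 log units) apart, beyond the scatter of two such steps. Compound 2 gives > 10000 nM, which is a limit of the assay and not a number, so the earlier step has a known direction but no exact size. Going by these compounds alone, with only one pair on each core, this shows that the outcome of the change depends on the core it is made on, but it does not show why, nor how the change would behave on any further core.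

The compounds shown leave open whether a longer chain on the same oxygen, such as ethyl or propyl, would follow the same split between the two cores. They also leave open how an amine in place of the hydroxy group would fare on either core.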